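The source may report more compounds than this note shows. Statements on the series, on what has been measured and on what is new or still open speak of the compounds shown alone.

Working notes on the series. In a functional assay on A2780 cells (Homo sapiens) for inhibition, read by MTT assay, with a stated time of 72 h (a higher number here means a weaker inhibitor of growth, a lower number a stronger inhibitor of growth), compound 1 `N#C/C(=C\c1c(F)c(F)c(F)c(F)c1F)C(=O)c1c[nH]c2ccccc12` gives 11000 nM. Compound 2 `COc1ccc(CNC(=O)/C(C#N)=C/c2ccco2)cc1` gives 24000 nM in this assay, the higher of the two numbers measured, with compound 1 as the nearer of them. Compound 3 `N#C/C(=C\c1ccco1)C(=O)NCc1ccc(Cl)c(Cl)c1` reaches only > 50000 nM, a limit of the assay and not a number (the limit of > 50000 nM in this assay, at which 1 of the 3 values shown sits). The step under study leads from compound 2 to compound 4 `COc1ccc(CNC(=O)/C(C#N)=C/c2ccc(-c3ccccc3)o2)cc1`: phenyl in place of hydrogen on an aromatic carbon of a five-membered aromatic ring with one oxygen. Among the measured compounds shown here, no measured pair in the set carries this change, so the size of the step in this assay rests on expectation alone; a modest gain, just beyond the scatter, is expected. The value for compound 4 is estimated at 15000 nM, between 4000 nM and 50000 nM. The expected step from compound 2 to compound 4 is a 1.6-fold lower number from compound 2 to compound 4 (0.20 log units; within the scatter).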

Compound 4, concentration for 50% growth inhibition: > 100000 nM
Compound 4: a limit, no number; the forecaster's own chance of this, stated with the estimate: 25%; middle value at least 6.6-fold (0.82 log units) away from the limit.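

Phenyl in place of hydrogen on an aromatic carbon of the five-membered aromatic ring with 1 oxygen, next to the ring oxygen, weakens growth inhibition in this assay, with an at least 4.1-fold higher number from compound 2 to compound 4 (0.61 log units; beyond the scatter). Among the compounds shown here, this is the first single-place change, and it shows that this position does not accept phenyl without loss. For compound 4 the reading is a limit and not a number: the limit of > 100000 nM in this assay, at which 1 of the 4 values shown sits.

From the compounds shown here alone, whether a smaller group at this carbon, such as methyl or a single chlorine atom, keeps the activity of compound 2 stays open. So does whether an amine on the added phenyl would recover growth inhibition.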